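Cytotoxicity notes: pyridinyloxy to phenoxy swap in the series

A few compounds are considered here, and "the series" means these few. Any claim that something is new, unique, unknown or untested is made for them only; others in the source may bear on it.

Measured compounds:
- compound 1 `CC(CCNC(=O)c1c(Cl)cncc1Cl)N1CCC(C(Oc2ccccn2)c2ccc(C(F)(F)F)cc2)CC1`: 34100 nM
- compound 2 `CCO/N=C(/c1ccc(Br)cc1)C1CCN(C(C)(C)CCNC(=O)c2c(Cl)cncc2Cl)CC1`: 34000 nM
- compound 3 `CCO/N=C(/c1ccc(Br)cc1)C1CCN(C(CC)CCNC(=O)c2c(C)cc[n+]([O-])c2C)CC1`: > 177000 nM

In an ADME assay on PBMC cells (Homo sapiens) for cytotoxicity (a lower number here means that less compound is tolerated, a higher number that more compound is tolerated), compound 1 gives 34100 nM. In this assay compound 2 gives 34000 nM, and the two numbers sit within the scatter of each other, so no order between compound 1 and compound 2 can be read from them. Among the compounds with values here, for compound 3 this assay returns only a limit, > 177000 nM, not a number; it is the one value of the three that stands at the limit described by the limit of > 177000 nM in this assay, at which 1 of the 3 values shown sits. Within the data shown here, no single-point step between measured compounds is available in this set, and compound 3 shares with compound 1 neither the amide part nor the chain on the ring nitrogen, so its limit gives no direct guide to the change below.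

The next compound is compound 4 `CC(CCNC(=O)c1c(Cl)cncc1Cl)N1CCC(C(Oc2ccccc2)c2ccc(C(F)(F)F)cc2)CC1`. It differs from compound 1 at one place: phenyl in place of pyridin-2-yl on an oxygen on a saturated carbon. Within this series there is nothing to suggest that this exchange moves tolerated concentration, so the step from compound 1 to compound 4 is expected to be none beyond the scatter, a 1.1-fold lower number from compound 1 to compound 4 (0.06 log units; within the scatter). Compound 4 is therefore estimated at 30000 nM in this assay, within a range from 12000 nM to 80000 nM.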

Compound 4, half-maximal cytotoxic concentration: 6800 nM
Compound 4: middle estimate off by 4.4-fold (0.64 log units), on the high side; the measured number lies below the stated range.
By their numbers in this assay, from the lowest: compound 4; then compounds 2 and 1 (each within the scatter of the next). At a limit, above all of these: compound 3.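

In this assay, within the data shown here, the exchange of pyridin-2-yl for phenyl on an oxygen on a saturated carbon gives a 5.0-fold lower number from compound 1 to compound 4 (0.70 log units; beyond the scatter) and so provides the first single-point step in the set, showing that this position is not neutral for tolerated concentration. By the counts the change is small: both groups are six-membered aromatic rings with no net charge and 0 hydrogen-bond donors, while pyridin-2-yl carries 1 hydrogen-bond acceptor and phenyl carries 0. No measurement at hand bears on why the step occurs.

Open, from the compounds shown here alone, is where a pyridin-3-yl or pyrimidin-2-yl group on the same oxygen would fall relative to compound 1 and compound 4, which would show whether the result depends on a ring nitrogen and on where that nitrogen sits. Also open, going by these compounds, is whether the same exchange gives a step of similar size with a different amide part or a different chain on the ring nitrogen, since this single pair shares one background only.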